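Bridging the Ring Amine on the Shared Core

This account rests on a few compounds, and the source may have more. Where it says the series, first, only, none or still open, it means among the compounds named here.

Among the measured compounds shown here, compound 2 `CC1CCN(c2ccc3cc(NC(=O)CCc4ccc(C(F)(F)F)cc4)ccc3n2)C1` stands second highest of the three numbers so far in a functional assay on HEK293 cells for activation of melanin-concentrating hormone receptor 1 (Rattus norvegicus), read by inositol phosphate accumulation; on this read-out lower numbers stand for an effect already at smaller amounts and higher numbers for an effect only at larger amounts of compound; in that assay compound 2 gives 400 nM. Its nearest neighbour is compound 3 `Nc1ccc2cc(NC(=O)CCc3ccc(C(F)(F)F)cc3)ccc2n1`, which gives 720 nM, and the step of a 1.8-fold higher number from compound 2 to compound 3 (0.26 log units; within the scatter) stays within the scatter. Furthest from it is compound 1 `CC(C)N(C)c1ccc2cc(NC(=O)CCc3ccc(C(F)(F)F)cc3)ccc2n1`, which gives 140 nM; the step of a 2.9-fold higher number from compound 1 to compound 2 (0.46 log units; beyond the scatter) was a modest move beyond the scatter, and the step of a 5.1-fold higher number from compound 1 to compound 3 (0.71 log units; beyond the scatter) was the larger one.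

Compound 4 `O=C(CCc1ccc(C(F)(F)F)cc1)Nc1ccc2nc(N3CC4CCC3C4)ccc2c1` differs from compound 2 in one place: a group of 7 heavy atoms (6 carbon, 1 nitrogen; one five-membered non-aromatic ring of carbon only, one five-membered non-aromatic ring with 1 hetero atom) in place of a group of 6 heavy atoms (5 carbon, 1 nitrogen; one five-membered non-aromatic ring with 1 hetero atom), on an aromatic carbon. The entering group keeps the nitrogen attached to the aromatic carbon and adds a five-membered non-aromatic ring of carbon only.

For the measured compounds named here, two measured steps bear on this position. Changing from isopropyl(methyl)amino to 3-methylpyrrolidin-1-yl raised the number modestly, and changing from 3-methylpyrrolidin-1-yl to amino moved it only within the scatter. Nothing measured here shows what adding a further ring of carbon only does. The step from compound 2 to compound 4 is therefore expected to be small, a 1.3-fold higher number from compound 2 to compound 4 (0.10 log units; within the scatter), with little confidence in its direction. Compound 4 is estimated at 500 nM, within a range from 180 nM to 1500 nM.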

Compound 4, half-maximal effective concentration: 150 nM
Estimate against measurement, compound 4: 3.3-fold (0.52 log units) above, and the stated range ends above it.
By their numbers in this assay, from the lowest: compounds 1 and 4 (each within the scatter of the next); then compounds 2 and 3 (each within the scatter of the next).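

In this assay, among the compounds shown here, the added ring of carbon only takes the number the opposite way from what the earlier steps at this position might have suggested, with a 2.7-fold lower number from compound 2 to compound 4 (0.43 log units; beyond the scatter) and, against the unsubstituted amino group, a 4.8-fold lower number from compound 3 to compound 4 (0.68 log units; beyond the scatter) as the readings. The step of a 1.1-fold higher number from compound 1 to compound 4 (0.03 log units; within the scatter) places the open-chain isopropyl(methyl)amino group and the entering group with its two five-membered rings at one level, so a ring that takes in the nitrogen on this aromatic carbon does not in itself go with a higher number, which compound 2 alone had left possible. Nothing measured here explains why 3-methylpyrrolidin-1-yl and the entering group differ on this carbon next to the ring nitrogen.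

As far as these compounds go, how a piperidine or a morpholine ring on this aromatic carbon would compare with compound 4 remains open. So does whether a pyrrolidine without the methyl group would fall with compound 2 or with compound 4, and whether a smaller open-chain dimethylamino group would keep the level of compound 1.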